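This account rests on a few compounds, and the source may have more. Where it says the series, first, only, none or still open, it means among the compounds named here.

Measured in a functional assay on Huh-7 cells (Homo sapiens) for cytotoxicity, read by sulforhodamine B assay, with a stated time of 72 h; on this read-out lower numbers stand for stronger inhibition and higher numbers for weaker inhibition:
- compound 1 `Cc1ccc(-c2cc(C(=O)Nc3ccncc3)nn2-c2ccc3ccccc3n2)cc1`: 8000 nM
- compound 2 `Cc1ccc(-c2cc(C(=O)Nc3ccc(Cl)nc3Cl)nn2-c2ccc3ccccc3n2)cc1`: 14000 nM
- compound 3 `Cc1ccc(-c2cc(C(=O)Nc3ccnc(Cl)c3)nn2-c2ccc3ccccc3n2)cc1`: 1600 nM

Compound 3 gives the lowest number of the three, and its steps to both others lie beyond the scatter. The next change leads to compound 4 `COc1ncccc1NC(=O)c1cc(-c2ccc(C)cc2)n(-c2ccc3ccccc3n2)n1`: 2-methoxypyridin-3-yl in place of 2-chloropyridin-4-yl on an amide-type nitrogen. The 2-chloropyridin-4-yl group leaves, and 2-methoxypyridin-3-yl enters on an amide-type nitrogen.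

Going by the values given here, three measured steps bear on this. Two are modest and end on the 2-chloropyridin-4-yl group: a 5.0-fold lower number from compound 1 to compound 3 (0.70 log units; beyond the scatter), and an 8.8-fold lower number from compound 2 to compound 3 (0.94 log units; beyond the scatter). The third, a 1.8-fold higher number from compound 1 to compound 2 (0.24 log units; within the scatter), shows that the two compounds without that group do not separate. Among the compounds with values here, no measured compound carries 2-methoxypyridin-3-yl, so its own contribution is unknown. The low number of compound 3 is therefore expected to be lost, at a size like the two modest steps. In this assay, the estimated change is a rise of modest size: a 4.4-fold higher number from compound 3 to compound 4 (0.64 log units; beyond the scatter). Compound 4 is expected at 7000 nM, with an estimated range of 2500 nM to 20000 nM.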

Compound 4, half-maximal inhibitory concentration: 7900 nM
Compound 4: middle estimate off by 1.1-fold (0.05 log units), on the low side; low and high end bracket the measured number.
By their numbers in this assay, from the lowest: compound 3; then compounds 4, 1 and 2 (each within the scatter of the next).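

In this assay, 2-methoxypyridin-3-yl on the amide-type nitrogen does not keep the low number seen with 2-chloropyridin-4-yl (a 4.9-fold higher number from compound 3 to compound 4 (0.69 log units; beyond the scatter)). The new group does not separate from the other two groups tested at this place (a 1.8-fold lower number from compound 2 to compound 4 (0.25 log units; within the scatter); a 1.0-fold lower number from compound 1 to compound 4 (0.01 log units; within the scatter)), so among the four compounds only compound 3 stands apart, with steps beyond the scatter to all three others. Nothing available explains why this one group differs from the rest.

Going by these compounds, it remains open whether the step depends on the chloro group alone or would also appear with a bromo, methyl or amino group in its place on the pyridin-4-yl ring. A plain phenyl ring on the amide-type nitrogen would also show whether the pyridine nitrogen matters to the read-out here.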